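The source may report more compounds than this note shows. Statements on the series, on what has been measured and on what is new or still open speak of the compounds shown alone.

The measured compounds in an ADME assay on MT4 cells (Homo sapiens) for cytotoxicity, read by MTT assay, with a stated time of 5 days; on this read-out lower numbers stand for higher toxicity in this test and higher numbers for lower toxicity in this test:

Compound 1 `CCC(CC)Nc1cc(Oc2c(OC)cc3cc(C#N)ccc3c2OC)nc(Nc2ccc(C#N)cc2)n1` gives > 125000 nM, which is a limit of the assay.
Compound 2 `COc1cc2cc(C#N)ccc2c(OC)c1Oc1cc(NCC(C)(C)C)nc(Nc2ccc(C#N)cc2)n1` gives > 125000 nM, which is a limit of the assay.
Compound 3 `COc1cc2cc(C#N)ccc2c(OC)c1Oc1cc(NCC2CC2)nc(Nc2ccc(C#N)cc2)n1` gives > 125000 nM, which is a limit of the assay.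

Compound 3 therefore stands at the ceiling of what this assay reports, together with the two other measured compounds, and no number separates any of the three. The steps among them are a step that the two limits leave unreadable from compound 1 to compound 2, a step that the two limits leave unreadable from compound 1 to compound 3 and a step that the two limits leave unreadable from compound 2 to compound 3, none of which can be sized because of the limit of > 125000 nM in this assay, at which 3 of the 3 values shown sit.

Compound 4 `COc1cc2cc(C#N)ccc2c(OC)c1Oc1cc(NCC(O)CO)nc(Nc2ccc(C#N)cc2)n1` is not yet measured. It differs from compound 3 by 1,2-dihydroxyethyl in place of cyclopropyl on a saturated chain carbon bound to a nitrogen on an aromatic ring. No measured step gives a readable size for a change of the group on a nitrogen on an aromatic ring, since every one of them lies behind the limit. Within the data shown here, the only guide is that compound 3 and both its measured neighbours sit at that limit, so compound 4 is expected to stay there as well, and the step that the limit leaves unreadable from compound 3 to compound 4 is expected to be unreadable in turn. Compound 4 is estimated at 150000 nM, within 90000 nM to 300000 nM.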

Compound 4, half-maximal cytotoxic concentration: 29500 nM
Estimate against measurement, compound 4: 5.1-fold (0.71 log units) above; the whole stated range lies above it.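

In this assay, among these compounds, the group at this place can move the read-out, which the earlier compounds could not show: 1,2-dihydroxyethyl in place of cyclopropyl gives an at least 4.2-fold lower number from compound 3 to compound 4 (0.62 log units; beyond the scatter), the same group in place of tert-butyl gives an at least 4.2-fold lower number from compound 2 to compound 4 (0.62 log units; beyond the scatter), and 2,3-dihydroxypropyl in place of pentan-3-yl gives an at least 4.2-fold lower number from compound 1 to compound 4 (0.62 log units; beyond the scatter). Among the compounds shown here, all three steps are minimum sizes and point the same way, with the one group that carries oxygen being the only one to give a number. The steps among compound 1, compound 2 and compound 3 still cannot be read: the limit of > 125000 nM in this assay, at which 3 of the 4 values shown sit.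

On these data alone, it remains open whether both hydroxyl groups are needed, or whether a single hydroxyl on a shorter chain would give a similar step. As far as these compounds go, it is also open whether an amine or a carboxylic acid at this place would lower the number.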